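Thiosemicarbazone Isatin Derivatives in a Cell Tolerance Screen

The source may hold more compounds than are shown below. What is called first, only, known or untested is meant among the compounds shown, and "the series" means these compounds.

Four compounds share one core, a diethylaminomethyl-substituted lactam carrying a thiosemicarbazone arm. Compound 1 `CCN(CC)CN1C(=O)/C(=N/NC(N)=S)c2cc(Cl)ccc21` bears a chloro group and a free amino terminus. Compound 2 `CCN(CC)CN1C(=O)/C(=N/NC(=S)Nc2ccc(C)cc2)c2ccccc21` carries a 4-methylphenyl on the thiourea nitrogen and no chloro. Compound 3 `CCN(CC)CN1C(=O)/C(=N/NC(=S)Nc2ccc(C)cc2)c2cc(Cl)ccc21` has both the chloro and the 4-methylphenyl. Compound 4 `CCN(CC)CN1C(=O)/C(=N/NC(N)=S)c2ccccc21` has neither.

In an ADME assay on MDCK cells (Canis lupus familiaris) for cytotoxicity (a higher number here means that more compound is tolerated, a lower number that less compound is tolerated), compound 1 gives 100000 nM. Compound 2 gives 800 nM in this assay, the lowest of the three numbers, and compound 3 gives 4000 nM. The change from compound 3 to compound 1, hydrogen in place of 4-methylphenyl on an amide-type nitrogen, is the same change that takes compound 2 to compound 4; it occurs twice among these compounds. Its measured step is a 25-fold higher number from compound 3 to compound 1 (1.40 log units; beyond the scatter), which is described as hydrogen in place of 4-methylphenyl on an amide-type nitrogen. The two cores differ as hydrogen in place of chloro on an aromatic carbon, and the measured step for that difference is a 5.0-fold higher number from compound 2 to compound 3 (0.70 log units; beyond the scatter).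

The change to compound 4 reads (hydrogen in place of 4-methylphenyl on an amide-type nitrogen), with a place line identical to that of the earlier pair. He therefore expects the step from compound 2 to compound 4 to resemble the earlier one, a 25-fold higher number from compound 2 to compound 4 (1.40 log units; beyond the scatter), resting on compound 3 to compound 1 giving a 25-fold higher number from compound 3 to compound 1 (1.40 log units; beyond the scatter) and on compound 2 starting from 800 nM. For compound 4 in this assay he estimates 20000 nM, within 5000 nM to 100000 nM.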

Compound 4, minimum cytotoxic concentration: 100000 nM
Compound 4: the middle estimate sits 5.0-fold (0.70 log units) below what was measured; the measured number falls inside the stated range.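

In this assay, replacing 4-methylphenyl with hydrogen on the amide-type nitrogen gives a higher number on both cores, and on the core without chloro the step is a 130-fold higher number from compound 2 to compound 4 (2.10 log units; beyond the scatter), so the direction carries over but the size does not: the same change on two cores in this assay, a 25-fold higher number (1.40 log units; beyond the scatter) from compound 3 to compound 1 and a 130-fold higher number (2.10 log units; beyond the scatter) from compound 2 to compound 4, 5.0-fold (0.70 log units) apart, beyond the scatter of two such steps

The chloro change carries over less well, since hydrogen in place of chloro on an aromatic carbon gives no change at the digits printed from compound 1 to compound 4 (within the scatter), whereas the pair bearing 4-methylphenyl separates clearly: the same change on two cores in this assay, a 5.0-fold higher number (0.70 log units; beyond the scatter) from compound 2 to compound 3 and no change at the digits printed (within the scatter) from compound 4 to compound 1, 5.0-fold (0.70 log units) apart, beyond the scatter of two such steps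

These four compounds therefore show that neither step can be moved unchanged from one core to another here, but they do not show why the sizes differ, and a single pair of cores for each change gives no general rule for the series.

From the compounds shown here alone, it remains open how other groups on that amide-type nitrogen, such as an unsubstituted phenyl, a methyl or a longer alkyl chain, would fall between the amino terminus of compound 4 and the 4-methylphenyl of compound 2. Going by these compounds, it is equally open whether a fluoro or a methoxy group in place of chloro on the aromatic carbon would follow compound 3 or compound 1.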